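Fatty acyl chain length and cytotoxicity in the series

The source may report more compounds than this note shows. Statements on the series, on what has been measured and on what is new or still open speak of the compounds shown alone.

Values in a functional assay on MDA-MB-231 cells (Homo sapiens) for cytotoxicity, read by MTT assay, with a stated time of 24 h; on this read-out higher numbers stand for weaker inhibition and lower numbers for stronger inhibition:
- Compound 1 `CCCCCCCCCCCCCCCCCC(=O)Nc1nnc(S[C@@H]2O[C@H](CO)[C@H](O)[C@H](O)[C@H]2O)s1`: 67100 nM
- Compound 2 `CCCCCCCC/C=C\CCCCCCCC(=O)Nc1nnc(S[C@@H]2O[C@H](CO)[C@H](O)[C@H](O)[C@H]2O)s1`: 43600 nM
- Compound 3 `CCCCCC(=O)Nc1nnc(S[C@@H]2O[C@H](CO)[C@H](O)[C@H](O)[C@H]2O)s1`: 28700 nM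
- Compound 4 `CCCCCCCC/C=C\CCCCCCCCCCCC(=O)Nc1nnc(S[C@@H]2O[C@H](CO)[C@H](O)[C@H](O)[C@H]2O)s1`: not yet measured

Compound 1 holds the highest of the three numbers, with a 1.5-fold lower number from compound 1 to compound 2 (0.19 log units; within the scatter) as its nearest gap and a 2.3-fold lower number from compound 1 to compound 3 (0.37 log units; beyond the scatter) as its furthest. Compound 4 carries dec-1-en-1-yl in place of hexyl on a saturated chain carbon, ten or more bonds along the chain from a carbonyl carbon. Going by the values given here, the nearest precedent brings in the same dec-1-en-1-yl group on a different chain carbon, and that step from compound 1 stayed within the scatter. The other chain step, a 1.5-fold lower number from compound 2 to compound 3 (0.18 log units; within the scatter) as well, is small. The expected step is a 1.2-fold lower number from compound 1 to compound 4 (0.09 log units; within the scatter) and nothing beyond the scatter is expected. In this assay the estimate for compound 4 is 55000 nM with 27000 nM to 110000 nM as the expected range.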

Compound 4, half-maximal inhibitory concentration: 70400 nM
Beside the measured number, compound 4's estimate is 1.3-fold (0.11 log units) below it, within the range that was stated.
By their numbers in this assay, from the lowest: compounds 3, 2, 1 and 4 (each within the scatter of the next, the first and the last beyond it).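

Dec-1-en-1-yl in place of hexyl on a saturated chain carbon gives a 1.0-fold higher number from compound 1 to compound 4 (0.02 log units; within the scatter) in this assay and so shows no change that can be read at this place. The earlier dec-1-en-1-yl step was made on a different chain carbon, so this result extends the same flat reading to a new chain position. No measurement of any property bears on this result.

The compounds shown leave open whether an amine or a carboxylic acid at this place on the chain would move the number. Going by these compounds alone, they also leave open whether a chain shorter than the one in compound 3 would do so.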